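Methoxy for Methyl on the Anilide of Compound 1

The compounds below may be only part of what the source reports. "The series", "measured", "known", "first", "only" and "open" are said of these compounds alone.

Measured compounds:
compound 1 `Cc1ccccc1NC(=O)Cn1cc(COc2ccc3c(c2)CCC3)nn1`: "not determined" (no result reported) in an ADME assay on HEK293 cells (Homo sapiens) for inhibition, read by MTT assay, with a stated time of 48 h, tested at 25 uM; on this read-out higher numbers stand for more inhibition at the one concentration tested (going by the name of the read-out) and lower numbers for less inhibition
compound 2 `COc1cccc(-n2cc(COc3ccc4c(c3)CCC4)nn2)c1`: 25.8% in this assay

From the compounds shown here alone, compound 1 shares its core with compound 2 but has no single number, so where compound 1 stands in this assay is unknown; compound 2 alone gives 25.8% there. Compound 3 `COc1ccccc1NC(=O)Cn1cc(COc2ccc3c(c2)CCC3)nn1` differs from compound 1 by methoxy in place of methyl on an aromatic carbon. Without a measured pair of this kind, the step expected in this assay is none beyond the scatter, in no fixed direction. Resting only on compound 2, compound 3 is estimated to give 22%, within a range from 0% to 45%.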

Compound 3, a percentage reported as inhibition, at one concentration (the size of the read-out at that concentration, not a potency): 23.4%
Compound 3: middle estimate off by 1.4 percentage points, on the low side; the measured number falls inside the stated range.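

Among these compounds, compound 1 has no single number in this assay so no step to compound 3 can be read. From the compounds shown here alone, what methoxy in place of methyl does on this anilide stays open. Nothing available bears on the result of compound 3.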